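The source may hold more compounds than are shown below. What is called first, only, known or untested is meant among the compounds shown, and "the series" means these compounds.

Series notes. Compound 1 `O=C(Nc1ccc(-n2ccc3nc(C(=O)NCc4ccccc4)ccc32)cc1)Nc1cccc(Cl)c1Cl` in a functional assay on A375P cells (Homo sapiens) for cytotoxicity, read by MTT assay (a lower number here means a stronger inhibitor, a higher number a weaker inhibitor), reports only a limit, > 10000 nM, and so gives no number. Compound 2 `COC(=O)c1ccc2c(ccn2-c2ccc(NC(=O)Nc3ccc(Cl)c(C(F)(F)F)c3)cc2)n1` gives 3600 nM in this assay. Compound 3 `COC(=O)c1ccc2c(ccn2-c2ccc(NC(=O)c3ccc(Cl)c(C(F)(F)F)c3)cc2)n1` gives 3000 nM in this assay, the lowest of the two numbers shown; compound 2 sits within the scatter of it, so no order between the two is claimed. Compound 4 `COC(=O)c1ccc2c(ccn2-c2ccc(NC(=O)Nc3cccc(Cl)c3Cl)cc2)n1` is not yet measured. From compound 3 it differs in one place: (2,3-dichlorophenyl)amino in place of 4-chloro-3-(trifluoromethyl)phenyl on a carbonyl carbon. Compound 2 and compound 3 differ at the same carbonyl carbon by an amino linkage alone, and their values lie within the scatter. For the measured compounds named here, for the change of the chlorinated ring itself no measured step exists; compound 1 shows only (the limit of > 10000 nM in this assay, at which 1 of the 3 values shown sits). The step from compound 3 to compound 4 is expected to be modest and towards weaker inhibition, a 1.8-fold higher number from compound 3 to compound 4 (0.26 log units; within the scatter). Compound 4 is expected to give 5500 nM, between 2000 nM and 20000 nM.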

Compound 4, half-maximal inhibitory concentration: 6400 nM
Beside the measured number, compound 4's estimate is 1.2-fold (0.07 log units) below it, and the stated range covers the measured number.
By their numbers in this assay, from the lowest: compounds 3, 2 and 4 (each within the scatter of the next, the first and the last beyond it). At a limit, above all of these: compound 1.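

In this assay 2,3-dichlorophenyl in place of 4-chloro-3-(trifluoromethyl)phenyl on an amide-type nitrogen leaves no readable change (a 1.8-fold higher number from compound 2 to compound 4 (0.25 log units; within the scatter)). For the compounds shown here, the full change on the carbonyl carbon, (2,3-dichlorophenyl)amino for 4-chloro-3-(trifluoromethyl)phenyl, gives the only step here beyond the scatter, and it is modest (a 2.1-fold higher number from compound 3 to compound 4 (0.33 log units; beyond the scatter)). Methoxy in place of benzylamino reads only as a floor (an at least 1.5-fold lower number from compound 1 to compound 4 (0.19 log units; that floor lies within the scatter)), since the value of compound 1 is a limit: (the limit of > 10000 nM in this assay, at which 1 of the 4 values shown sits).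

Open, on these data alone, is what a carboxylic acid in place of methoxy on that carbonyl carbon gives. Also open, as far as these compounds go, is what an unsubstituted phenyl on the amide-type nitrogen gives.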